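Solubility notes on a shared-core amine series

A few compounds are considered here, and "the series" means these few. Any claim that something is new, unique, unknown or untested is made for them only; others in the source may bear on it.

Measured so far:
- compound 1 `COc1cccc(CNCCCNc2ccnc3cc(Oc4ccccc4)ccc23)c1O`: 14500 nM
- compound 2 `CC(C)CCc1ccc2c(NCCCNCc3ccco3)ccnc2c1`: 4200 nM
- compound 3 `c1ccc(Oc2ccc3c(NCCCNCc4ccco4)ccnc3c2)cc1`: 14500 nM

In a physicochemical assay for solubility, with a stated time of 18 h, at pH 7.4 (on this read-out higher numbers stand for higher solubility and lower numbers for lower solubility), compound 1 gives 14500 nM and stands level with compound 3 at the digits shown; together they hold the highest numbers of the three. The step of no change at the digits printed from compound 1 to compound 3 (within the scatter) shows that exchanging the group on the saturated chain carbon bound to the amine nitrogen leaves this assay unmoved. The step of a 3.5-fold higher number from compound 2 to compound 3 (0.54 log units; beyond the scatter), by contrast, shows that the group on the aromatic carbon of the shared core does move the read-out.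

Compound 4 `COc1ccc(Oc2ccc3c(NCCCNCc4cccc(OC)c4O)ccnc3c2)cc1` is not yet measured. It differs from compound 1 by methoxy in place of hydrogen on an aromatic carbon — read one bond further out, phenoxy becomes 4-methoxyphenoxy. For the measured compounds named here, no measured pair carries this exact change. Going by the values given here, the only step touching the aryl side is the phenoxy-for-isopentyl exchange, which is a different kind of swap and bears on it only loosely, while the step from compound 1 to compound 3 concerns the other end of the molecule. The change is small in atom count and without charge, so no step beyond the scatter is expected in this assay; the estimated step is a 1.3-fold lower number from compound 1 to compound 4 (0.12 log units; within the scatter), leaning if anything slightly downward. For compound 4 the expected value is 11000 nM, with a range from 5000 nM to 25000 nM.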

Compound 4, solubility: 14500 nM
Estimate against measurement, compound 4: 1.3-fold (0.12 log units) below; low and high end bracket the measured number.
By their numbers in this assay, from the lowest: compound 2; then compounds 1, 3 and 4 (each within the scatter of the next).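

In this assay, adding methoxy in place of hydrogen on the phenoxy ring, para to a large group, gives no change at the digits printed from compound 1 to compound 4 (within the scatter). The earlier step between compounds 2 and 3 showed that replacing the whole group on the shared core with phenoxy can move the read-out, whereas this result shows that a small uncharged addition at the far end of that phenoxy does not register beyond the scatter. The phenoxy ring of compound 1 therefore accepts the change to 4-methoxyphenoxy without a detectable shift in this read-out, although this rests on a single pair, and nothing at hand explains the flat result.

As far as these compounds go, it remains open whether a carboxylic acid or an amine in place of the methoxy, or a longer chain such as butoxy at the same place, would also leave the read-out flat. For the compounds shown here, it is equally open whether 4-methoxyphenoxy would behave the same way with the isopentyl compound's furan-2-yl side chain, since the only pair carrying this change has the 2-hydroxy-3-methoxyphenyl group at the other end.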